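A Sulfonyl Aryl Exchange on the Chloro Compound

The source may report more compounds than this note shows. Statements on the series, on what has been measured and on what is new or still open speak of the compounds shown alone.

In a functional assay on LOX IMVI cells (Homo sapiens) for cytotoxicity, read by MTT assay, with a stated time of 24 h (on this read-out higher numbers stand for weaker inhibition and lower numbers for stronger inhibition), compound 1 (`COc1cc(-c2nc(-c3ccccc3)[nH]c2-c2ccnc(NCCCNS(=O)(=O)c3ccc(Br)cc3)n2)ccc1F`) gives 33900 nM while compound 2 (`COc1cc(-c2nc(-c3ccccc3)[nH]c2-c2ccnc(NCCCNS(=O)(=O)c3cccc(F)c3)n2)ccc1F`) gives 900 nM and compound 3 (`COc1cc(-c2nc(-c3ccccc3)[nH]c2-c2ccnc(NCCCNS(=O)(=O)c3ccc(Br)cc3)n2)ccc1Cl`) gives 23700 nM on the same read-out. Compound 3 thus lies within the scatter of compound 1, and its number is far higher than that of compound 2. Compound 4 (`COc1cc(-c2nc(-c3ccccc3)[nH]c2-c2ccnc(NCCCNS(=O)(=O)c3cccc(F)c3)n2)ccc1Cl`) differs from compound 3 in one place, with 3-fluorophenyl in place of 4-bromophenyl on a sulfonyl sulfur. The same exchange has one measured precedent (a 38-fold lower number from compound 1 to compound 2 (1.58 log units; beyond the scatter)), a large step. Chloro in place of fluoro on an aromatic carbon made only a small difference (a 1.4-fold lower number from compound 1 to compound 3 (0.16 log units; within the scatter)), so that precedent is expected to carry over, although no measured pair tests this. A step of similar size towards a lower number is therefore expected (a 36-fold lower number from compound 3 to compound 4 (1.56 log units; beyond the scatter)) in this assay for this exchange. Compound 4 is estimated at 650 nM with an expected range of 220 nM to 2000 nM on this evidence.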

Compound 4, half-maximal inhibitory concentration: 5110 nM
Compound 4: the middle estimate sits 7.9-fold (0.90 log units) below what was measured; the whole stated range lies below it.
By their numbers in this assay, from the lowest: compound 2; then compound 4; then compounds 3 and 1 (each within the scatter of the next).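

In this assay, 3-fluorophenyl in place of 4-bromophenyl on a sulfonyl sulfur also lowers the number when chloro replaces fluoro on the core, giving a 4.6-fold lower number from compound 3 to compound 4 (0.67 log units; beyond the scatter), but the size of this step depends on that core: the same change on two cores in this assay, a 38-fold lower number (1.58 log units; beyond the scatter) from compound 1 to compound 2 and a 4.6-fold lower number (0.67 log units; beyond the scatter) from compound 3 to compound 4, 8.1-fold (0.91 log units) apart, beyond the scatter of two such steps. Chloro in place of fluoro on an aromatic carbon, which stayed within the scatter with 4-bromophenyl on the sulfonyl sulfur, has a modest effect with 3-fluorophenyl there, giving a 5.7-fold higher number from compound 2 to compound 4 (0.75 log units; beyond the scatter): the same change on two cores in this assay, a 1.4-fold lower number (0.16 log units; within the scatter) from compound 1 to compound 3 and a 5.7-fold higher number (0.75 log units; beyond the scatter) from compound 2 to compound 4, 8.1-fold (0.91 log units) apart, beyond the scatter of two such steps. In these four compounds, the two changes therefore do not act independently of each other.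

The compounds shown leave open whether the halogen or its place on the ring carries the step, a question that 3-bromophenyl or 4-fluorophenyl on the sulfonyl sulfur would separate. They also leave open how an unsubstituted phenyl there, or a longer chain on the sulfonamide nitrogen, would behave on either core.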